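This account rests on a few compounds, and the source may have more. Where it says the series, first, only, none or still open, it means among the compounds named here.

Compound 2 `O=C(Nc1nc(-c2ccccc2)nc2c1nnn2Cc1ccccc1)c1cccc(F)c1` carries a 3-fluorophenyl group on the carbonyl carbon of its amide. Among the compounds with values here, in an assay on CHO cells for displacement of a labelled ligand from adenosine receptor A3 (Homo sapiens), read by scintillation counting (on this read-out higher numbers stand for weaker inhibition and lower numbers for stronger inhibition), compound 2 gives 5810 nM, the highest of the two numbers known so far. Within the data shown here, its only neighbour is compound 1 `O=C(Nc1nc(-c2ccccc2)nc2c1nnn2Cc1ccccc1)c1ccccc1C(F)(F)F`, which differs from it in that same place, carrying a 2-(trifluoromethyl)phenyl group there; in this assay compound 1 gives 560 nM. The step of a 10-fold higher number from compound 1 to compound 2 (1.02 log units; beyond the scatter) shows how much the choice of group on that carbonyl carbon can matter.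

Compound 3 `O=C(Nc1nc(-c2ccccc2)nc2c1nnn2Cc1ccccc1)C1CCCC1` takes the change one step further: cyclopentyl in place of 3-fluorophenyl on a carbonyl carbon. Among the measured compounds shown here, only one measured step bears on this position, from compound 1 to compound 2, and it exchanges one aromatic group for another, so the move to a non-aromatic five-membered ring has no direct precedent here. Given that this single step was large, a sizable change in this assay is possible in either direction; the expectation leans towards a lower number, with a 3.9-fold lower number from compound 2 to compound 3 (0.59 log units; beyond the scatter) as the estimated step. Compound 3 is therefore expected to give about 1500 nM in this assay, in an estimated range from 250 nM to 9000 nM.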

Compound 3, inhibition constant: 4690 nM
Compound 3: the middle estimate sits 3.1-fold (0.50 log units) below what was measured; the range from low to high includes it.
By their numbers in this assay, from the lowest: compound 1; then compounds 3 and 2 (each within the scatter of the next).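

Replacing the aromatic 3-fluorophenyl with the non-aromatic cyclopentyl on this carbonyl carbon gives a 1.2-fold lower number from compound 2 to compound 3 (0.09 log units; within the scatter), so in this assay these two groups cannot be told apart, even though they differ in ring type, in ring size and in the presence of fluorine. The result also places the earlier gap in a new light: an 8.4-fold higher number from compound 1 to compound 3 (0.92 log units; beyond the scatter) shows that the 2-(trifluoromethyl)phenyl of compound 1 stands apart from a non-aromatic ring as well as from the other aromatic ring, so having an aromatic ring here does not by itself decide the reading, and compound 2 goes against any such link. Nothing available here explains why compound 1 stands apart from the other two.

The compounds shown leave open whether that separation belongs to the trifluoromethyl group itself, which an unsubstituted phenyl or a 2-fluorophenyl on the same carbonyl carbon would help to settle. They also leave open how this position responds to an open chain such as butyl, or to a group carrying an amine or a carboxylic acid.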